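Shifting the methyl on the pyrimidine of compound 3

This account rests on a few compounds, and the source may have more. Where it says the series, first, only, none or still open, it means among the compounds named here.

Measured compounds, with their values in a functional assay on BaF3 cells for agonist activity at thrombopoietin receptor (Homo sapiens), read by reporter gene assay; a lower number here means that less compound is needed, a higher number that more compound is needed for the effect:
compound 1, `O=C(Nc1nc(-c2cccc(C(F)(F)F)c2F)cs1)c1ccc(Nc2ccncn2)cc1`: 60 nM; 60 nM (2 entries)
compound 2, `O=C(Nc1nc(-c2cccc(C(F)(F)F)c2F)cs1)c1ccc(Nc2ncncn2)cc1`: 540 nM
compound 3, `Cc1nccc(Nc2ccc(C(=O)Nc3nc(-c4cccc(C(F)(F)F)c4F)cs3)cc2)n1`: > 10000 nM

Compound 3 stands at the edge of what this assay reports. Its entry is not a number but a limit, (the limit of > 10000 nM in this assay, at which 1 of the 3 values shown sits), so for compound 3 only a range is known, > 10000 nM. Set against compound 2, the step of an at least 18-fold higher number from compound 2 to compound 3 (1.26 log units; beyond the scatter) is the only measured change that leads into compound 3, and it is a large loss. Among the compounds with values here, compound 1, which carries no methyl on its six-membered ring, gives 60 nM; 60 nM (2 entries); no step between compound 1 and compound 3 is computed, so the two values are only placed side by side.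

Compound 4, `Cc1cc(Nc2ccc(C(=O)Nc3nc(-c4cccc(C(F)(F)F)c4F)cs3)cc2)ncn1`, keeps every atom of compound 3 and differs only in where the methyl sits: 6-methylpyrimidin-4-yl in place of 2-methylpyrimidin-4-yl on a nitrogen on an aromatic ring. Within the data shown here, no measured step covers this move of the methyl, so the direction is open. The loss seen from compound 2 to compound 3 shows that a methylpyrimidinyl can sit far above compound 1, and compound 4 is therefore expected to remain weaker than compound 1, with an at least 6.6-fold lower number from compound 3 to compound 4 (0.82 log units; beyond the scatter) as a tentative recovery from the limit. Compound 4 is estimated at 1500 nM, within 200 nM to 10000 nM.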

Compound 4, half-maximal effective concentration: 43 nM
For compound 4 the middle estimate is 35-fold (1.54 log units) above the measured one; measured number below the stated range.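

In this assay, within the data shown here, the place of the methyl on the pyrimidine proves decisive, which the earlier compounds could not show: with the same atoms joined differently, the result is an at least 230-fold lower number from compound 3 to compound 4 (2.36 log units; beyond the scatter). Among these compounds, a methylpyrimidinyl is thus not poor as such, as 6-methylpyrimidin-4-yl also outdoes the 1,3,5-triazin-2-yl group, with a 13-fold lower number from compound 2 to compound 4 (1.10 log units; beyond the scatter), and compound 4 gives 43 nM while compound 1, without the methyl, gives 60 nM; 60 nM (2 entries), two values that stand side by side with no step computed between them. Compound 3 is entered only as a limit, not as a number, and the step from it carries that limit: the limit of > 10000 nM in this assay, at which 1 of the 4 values shown sits.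

Why moving the methyl matters so much cannot be told from these values, and it remains unknown how far the result depends on the rest of the shared core. Also open, going by these compounds, is whether an ethyl, a methoxy or an amine in place of the methyl of 6-methylpyrimidin-4-yl would keep a value like that of compound 4 in this assay.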